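The source may hold more compounds than are shown below. What is called first, only, known or untested is meant among the compounds shown, and "the series" means these compounds.

For the measured compounds named here, compound 2 `COc1ccc(Nc2ncnc3cc(OC)c(OCCCCC(=O)Nc4ccc(S(N)(=O)=O)cc4)cc23)cc1OC` gives 9230 nM in a functional assay on NCI-H1975 cells (Homo sapiens) for antiproliferative activity, read by MTT assay, with a stated time of 72 h (on this read-out higher numbers stand for weaker inhibition and lower numbers for stronger inhibition), the lowest of the two numbers known; the nearest is compound 1 `COc1cc2ncnc(Nc3cccc(Cl)c3)c2cc1OCCCCC(=O)Nc1ccc(S(N)(=O)=O)cc1`, which gives 33200 nM in this assay. Going by the values given here, the one measured step, a 3.6-fold lower number from compound 1 to compound 2 (0.56 log units; beyond the scatter), shows that swapping the aryl group on the nitrogen on the aromatic ring moves the read-out by a modest amount. Compound 3 `COc1cc2ncnc(Nc3ccccc3)c2cc1OCCCCC(=O)Nc1ccc(S(N)(=O)=O)cc1` is not yet measured; its change from compound 2 is phenyl in place of 3,4-dimethoxyphenyl on a nitrogen on an aromatic ring. Among the compounds with values here, the only step bearing on it is the one from compound 1 to compound 2, and it runs the other way here, since the 3,4-dimethoxyphenyl that brought the lower number is removed while no 3-chlorophenyl enters. Compound 3 is therefore expected to give a higher number than compound 2, though one that stays short of compound 1. For compound 3 the estimated step is a 2.2-fold higher number from compound 2 to compound 3 (0.34 log units; beyond the scatter). The estimate for compound 3 in this assay is 20000 nM, with a range of 8000 nM to 50000 nM.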

Compound 3, half-maximal inhibitory concentration: 14100 nM
The estimate for compound 3 lay 1.4-fold (0.15 log units) above the measured number; the measured number falls inside the stated range.
By their numbers in this assay, from the lowest: compounds 2 and 3 (each within the scatter of the next); then compound 1.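

In this assay, the plain phenyl of compound 3 sits close to the 3,4-dimethoxyphenyl of compound 2: a 1.5-fold higher number from compound 2 to compound 3 (0.18 log units; within the scatter), so the two methoxy groups are not needed to hold the number at this level on the nitrogen on an aromatic ring. The separation instead follows the chloro group, with a 2.4-fold lower number from compound 1 to compound 3 (0.37 log units; beyond the scatter) when hydrogen takes its place on the aromatic carbon, which means that the earlier step between compound 1 and compound 2 can be read mainly as the loss of the chloro group rather than a gain from the methoxy groups. Nothing measured here explains why the chloro group carries this cost.

As far as these compounds go, whether a fluoro group, a methyl group or an amine on the phenyl would track chloro or hydrogen remains open. So does whether a shorter chain would change these gaps on the shared core.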